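The compounds below may be only part of what the source reports. "The series", "measured", "known", "first", "only" and "open" are said of these compounds alone.

Of the compounds shown here, two have been measured so far. Compound 1 `COc1ccc2c(c1)CCc1ccc(OC)c(c1)Oc1ccc(cc1)-c1nc(N)sc1-c1cccc(c1)O2` gives 0% in a functional assay on KB/VCR cells (Homo sapiens) for cytotoxicity, read by MTT assay, with a stated time of 48 h, tested at 10 uM; a higher number here means more inhibition at the concentration tested (going by the name of the read-out), a lower number less inhibition. Compound 2 `Nc1nc2c(s1)-c1cccc(c1)Oc1ccc(O)cc1CCc1ccc(O)c(c1)Oc1ccc-2cc1` gives 0% in this assay. The two values are level with each other at the digits reported, and their gap lies within the usual scatter, so compound 1 stands alongside compound 2 with no inhibition recorded for either at the concentration tested.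

Compound 3 `COc1ccc2c(c1)CCc1ccc(OC)c(c1)Oc1ccc(cc1)-c1nc(NN)sc1-c1cccc(c1)O2` has not yet been measured. It differs from compound 1 in one place: amino in place of hydrogen on a nitrogen on an aromatic ring. Among the measured compounds shown here, no measured pair shows what a change at this nitrogen does to the read-out, and the one comparison available, between compound 1 and compound 2, shows a change elsewhere on the shared core leaving the value unmoved. Compound 3 is therefore expected to show only a small step, a number 4 percentage points higher from compound 1 to compound 3 (within the scatter), not clearly beyond the scatter, with a slight upward lean because compound 1 gives 0% and such a value can only move in one direction. Compound 3 is estimated at 4%, within a range from 0% to 18%.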

Compound 3, a percentage reported as inhibition, at one concentration (the size of the read-out at that concentration, not a potency): 0%
Estimate against measurement, compound 3: 4 percentage points above; low and high end bracket the measured number.
By their numbers in this assay, from the lowest: compounds 1, 2 and 3 (each within the scatter of the next).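

The first step read at this nitrogen, amino in place of hydrogen on a nitrogen on an aromatic ring, gives no change at the digits printed from compound 1 to compound 3 (within the scatter) in this assay. With this group in place, compound 3 gives 0%, so both the hydrogen and the amino at this position now have a reading, and neither shows inhibition at the concentration tested. Nothing measured bears on why the result falls as it does.

Since the read-out sits at zero for both compounds, this single step cannot say whether the position is indifferent to substitution or whether any inhibition would appear with another group there, and it gives no measure of how the two compounds compare at any other concentration. Open too is what an acetyl group or a longer chain such as a propyl group on the same nitrogen would give, or a carboxylic acid carried on such a chain, since the compounds shown hold only the hydrogen and the amino at this place.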